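The source may report more compounds than this note shows. Statements on the series, on what has been measured and on what is new or still open speak of the compounds shown alone.

Working notes on the series.

Three compounds on the shared core have been run in an ADME assay on PC-3 cells (Homo sapiens) for cytotoxicity, read by WST assay, tested at 100 uM; a lower number here means less inhibition, a higher number more inhibition at the concentration tested (going by the name of the read-out). Compound 1 `O=C(Nc1ccc(Cl)cn1)C1CCCN(C(=O)c2cc(C(F)(F)F)cc(C(F)(F)F)c2)C1` gives 0%, and compound 2 `O=C(Nc1cccc(Oc2ccccn2)c1)C1CCCN(C(=O)c2cc(C(F)(F)F)cc(C(F)(F)F)c2)C1` gives 0%. Compound 3 `C=Cc1cccc(C(=O)N2CCCC(C(=O)Nc3ccc(Cl)cc3)C2)c1` gives 0% in this assay, level with compound 1 and compound 2 at the digits read; the gap to each of them lies within the scatter, so nothing separates the three on these numbers.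

Compound 4 `CSc1cccc(C(=O)N2CCCC(C(=O)Nc3ccc(Cl)cc3)C2)c1` has not yet been measured in this assay. It differs from compound 3 in one place: methylsulfanyl in place of vinyl on an aromatic carbon. Among the compounds with values here, no step between measured compounds touches this change, so there is nothing in the data that predicts a shift in either direction, and the step from compound 3 to compound 4 is expected to be none beyond the scatter, no change at the digits printed from compound 3 to compound 4 (within the scatter). Compound 4 is therefore estimated at 0% in this assay, with a range from 0% to 12%, resting on compound 3 at 0%.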

Compound 4, a percentage reported as inhibition, at one concentration (the size of the read-out at that concentration, not a potency): 0%
The estimate for compound 4 equals the measured number at the digits printed, and the stated range covers the measured number.
By their numbers in this assay, from the lowest: compounds 1, 2, 3 and 4 (each within the scatter of the next).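

In this assay, methylsulfanyl in place of vinyl on an aromatic carbon gives no change at the digits printed from compound 3 to compound 4 (within the scatter). Within the data shown here, this is the first step between measured compounds that differ in one place. It shows that at this position, on a six-membered aromatic ring of carbon only and meta to a large group, a sulfur-bearing group with a hydrogen-bond acceptor can replace vinyl and its double bond without moving the read-out beyond the scatter. Nothing measured here accounts for this result.

From the compounds shown here alone, whether any group at this position can move the read-out remains open, for example an amine, a carboxylic acid or a longer chain on the same carbon. With all four compounds level at the digits printed, the compounds shown also leave open what on the shared core, if anything, would separate them in this assay.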